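The compounds below may be only part of what the source reports. "The series", "measured", "known", "first", "only" and "open" are said of these compounds alone.

For the measured compounds named here, in a functional assay on HeLa cells (Homo sapiens) for antiproliferative activity, with a stated time of 5 days (on this read-out higher numbers stand for weaker inhibition and lower numbers for stronger inhibition), compound 1 (`CC1OC2(C=CC(=O)C=C2)N(c2nc(-c3ccc4ccccc4c3)nn2-c2ccc3ccccc3c2)C1=O`) gives 300 nM and compound 2 (`CC1OC2(C=CC(=O)C=C2)N(c2nc(-c3ccc4ccccc4c3)nn2-c2ccccc2)C1=O`) gives 120 nM as the lower of the two numbers so far. Between them lies a 2.5-fold lower number from compound 1 to compound 2 (0.40 log units; beyond the scatter) as the only measured step, and it comes with phenyl in place of naphthalen-2-yl on an aromatic nitrogen. Compound 3 (`CC1OC2(C=CC(=O)C=C2)N(c2nc(-c3cccc4ccccc34)nn2-c2ccccc2)C1=O`) keeps that phenyl and instead carries naphthalen-1-yl in place of naphthalen-2-yl on an aromatic carbon. Going by the values given here, this carbon sits between two ring nitrogen atoms, and no measured step touches it. The step from compound 1 therefore bears on the change only indirectly, as a guide to size: a 2.5-fold lower number from compound 1 to compound 2 (0.40 log units; beyond the scatter) was modest, and it exchanged a whole aryl group, whereas here the same atoms are merely joined differently. A step no larger than that one is expected, most likely within the scatter, and its direction cannot be told from the data. The expected shift is a 1.3-fold higher number from compound 2 to compound 3 (0.10 log units; within the scatter) as a slight lean upward. For compound 3 the estimated value is 150 nM (expected range 60 nM to 400 nM).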

Compound 3, half-maximal inhibitory concentration: 110 nM
Compound 3: the middle estimate sits 1.4-fold (0.13 log units) above what was measured; the measured number falls inside the stated range.
By their numbers in this assay, from the lowest: compounds 3 and 2 (each within the scatter of the next); then compound 1.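

In this assay, for the compounds shown here, a 1.1-fold lower number from compound 2 to compound 3 (0.04 log units; within the scatter) gives the first reading at the aromatic carbon between two ring nitrogen atoms, and it shows that naphthalen-1-yl and naphthalen-2-yl cannot be told apart there when phenyl sits on the aromatic nitrogen. The two groups have the same atoms, joined differently, so at this position the point of attachment of the naphthalene makes no difference that this read-out can resolve, whereas the exchange of a whole aryl group on the aromatic nitrogen gave a 2.5-fold lower number from compound 1 to compound 2 (0.40 log units; beyond the scatter), beyond the scatter. No supporting data bear on why the two naphthalene groups read alike here.

Both groups seen on this carbon are naphthalenes, so the compounds shown leave open how far the read-out depends on having a large aromatic group there at all, as a plain phenyl, a morpholine or a carboxylic acid on the same carbon would test. Going by these compounds, it also remains open whether naphthalen-1-yl and naphthalen-2-yl would still read alike with naphthalen-2-yl rather than phenyl on the aromatic nitrogen.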